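The source may report more compounds than this note shows. Statements on the series, on what has been measured and on what is new or still open speak of the compounds shown alone.

In an ADME assay on HEK293 cells (Homo sapiens) for cytotoxicity, read by resazurin assay, with a stated time of 48 h (a lower number here means that less compound is tolerated, a higher number that more compound is tolerated), three compounds have been measured. Compound 1 `O=S(=O)(Nc1ccc(-c2nc3ccccc3o2)cc1)c1cccs1` reaches only the limit of the assay, > 100000 nM, not a number. Compound 2 `COc1ccc(S(=O)(=O)Nc2ccc(-c3nc4ccccc4o3)cc2)cc1` also sits at that limit, giving > 100000 nM. The step from compound 1 to compound 2, a step that the two limits leave unreadable from compound 1 to compound 2, therefore cannot be read in size. Going by the values given here, compound 3 `O=S(=O)(Nc1ccc2oc(-c3ccccc3)nc2c1)c1ccccc1C(F)(F)F` is the one compound with a real number in this assay, 80000 nM. It stands alone against the other two values, which sit at the limit of > 100000 nM in this assay, at which 2 of the 3 values shown sit.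

Compound 4 `O=S(=O)(Nc1ccc2oc(-c3ccccc3)nc2c1)c1ccccc1F` differs from compound 3 in a single place: fluoro in place of trifluoromethyl on an aromatic carbon. None of the measured steps concerns the group on this sulfonyl-bound ring, and the one step shown is unreadable, so no guide to the size of this change exists. The expectation is therefore a step within the scatter, a 1.3-fold higher number from compound 3 to compound 4 (0.10 log units; within the scatter), with a fair chance that compound 4 is again reported only as a limit. Compound 4 is estimated at 100000 nM, between 40000 nM and 300000 nM.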

Compound 4, half-maximal cytotoxic concentration: 72000 nM
For compound 4 the middle estimate is 1.4-fold (0.14 log units) above the measured one; the range from low to high includes it.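

In this assay, the group on an aromatic carbon of the six-membered ring, ortho to a large group, can be changed with a readable result: a 1.1-fold lower number from compound 3 to compound 4 (0.05 log units; within the scatter). Going by these compounds alone, this is the first step that can be read, as the earlier one, joining two limits, cannot. Going from the four heavy atoms of trifluoromethyl to the single atom of fluoro therefore leaves the tolerated concentration within the usual scatter, so in this pair the size of the group at this place makes no visible difference.

What the compounds shown leave open is whether a group of another kind at this place, such as an amine or a carboxylic acid, would shift the number beyond the scatter. It also remains open how far any of these compounds lie from compound 1 and compound 2, which give only limits: the limit of > 100000 nM in this assay, at which 2 of the 4 values shown sit.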